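From benzofuranyl to ethynyl on the shared core

A few compounds are considered here, and "the series" means these few. Any claim that something is new, unique, unknown or untested is made for them only; others in the source may bear on it.

In a functional assay on A549 cells (Homo sapiens), read by MTT assay, with a stated time of 72 h (a higher number here means a weaker inhibitor, a lower number a stronger inhibitor), compound 1 (`Cc1ncnc2c1c(-c1ccoc1)cn2[C@@H]1O[C@H](CO)[C@@H](O)[C@H]1O`) gives > 20000 nM as a limit of the assay. Compound 2 (`Cc1ncnc2c1c(-c1cccs1)cn2[C@@H]1O[C@H](CO)[C@@H](O)[C@H]1O`) gives > 20000 nM as a limit too. Compound 3 (`Cc1ncnc2c1c(-c1cc3ccccc3o1)cn2[C@@H]1O[C@H](CO)[C@@H](O)[C@H]1O`) gives > 20000 nM as a limit, and so stands at the limit of > 20000 nM in this assay, at which 3 of the 3 values shown sit, with no number of its own. Compound 4 (`C#Cc1cn([C@@H]2O[C@H](CO)[C@@H](O)[C@H]2O)c2ncnc(C)c12`) carries ethynyl in place of 1-benzofuran-2-yl on an aromatic carbon. The steps a step that the two limits leave unreadable from compound 1 to compound 2 and a step that the two limits leave unreadable from compound 1 to compound 3 and a step that the two limits leave unreadable from compound 2 to compound 3 have no readable size, so they set no size for this change. With compound 3 at > 20000 nM as its limit, any readable change is expected towards stronger inhibition, and another limit remains about as likely. The expected step is an at least 1.3-fold lower number from compound 3 to compound 4 (0.12 log units; that floor lies within the scatter) as a rough estimate. For compound 4 the estimate is 15000 nM with an expected range from 1500 nM to 40000 nM in this assay for now.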

Compound 4, half-maximal inhibitory concentration: 19200 nM
Compound 4: middle estimate off by 1.3-fold (0.11 log units), on the low side, within the range that was stated.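

In this assay, among the compounds shown here, ethynyl on this aromatic carbon gives the first value at this position that is a number and not a limit, but the steps are only floors within the scatter: an at least 1.0-fold lower number from compound 3 to compound 4 (0.01 log units; that floor lies within the scatter), an at least 1.0-fold lower number from compound 2 to compound 4 (0.01 log units; that floor lies within the scatter) and an at least 1.0-fold lower number from compound 1 to compound 4 (0.01 log units; that floor lies within the scatter). The steps among compound 1, compound 2 and compound 3 cannot be read. The ring groups therefore show no gain over ethynyl or loss against it, and most of the series stays at a limit: the limit of > 20000 nM in this assay, at which 3 of the 4 values shown sit.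

Open, going by these compounds, is whether an aminomethyl group or a carboxylic acid on this aromatic carbon would give a step beyond the scatter. Also open, on these data alone, is how far compound 1, compound 2 and compound 3 lie past their limits.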